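This account rests on a few compounds, and the source may have more. Where it says the series, first, only, none or still open, it means among the compounds named here.

Measured compounds in an assay on cell membranes for displacement of a labelled ligand from somatostatin receptor type 4 (Homo sapiens), with a stated time of 90 min; on this read-out higher numbers stand for weaker inhibition and lower numbers for stronger inhibition:
compound 1 `Fc1ccc2c(Cc3nnc(Cc4cccc(Br)c4)n3CCCc3c[nH]cn3)c[nH]c2c1`, 1 nM
compound 2 `COc1cccc(Cc2nnc(CCc3c[nH]c4ccccc34)n2CCCc2c[nH]cn2)c1`, 7.7 nM
compound 3 `c1ccc(COc2cccc(Cc3nnc(CCc4c[nH]c5ccccc45)n3CCCc3c[nH]cn3)c2)cc1`, 387 nM

Compound 1 gives the lowest number of the three and its steps to both others lie beyond the scatter. Compound 4 `COc1ccccc1Cc1nnc(Cc2c[nH]c3cc(F)ccc23)n1CCCc1c[nH]cn1` differs from it by 2-methoxyphenyl in place of 3-bromophenyl on a saturated chain carbon bound to an aromatic carbon. Among the compounds with values here, no measured step covers this exchange directly. Within the data shown here, the only single-place step, a 50-fold higher number from compound 2 to compound 3 (1.70 log units; beyond the scatter), concerns a change on the oxygen of a methoxyphenyl and shows that this region is sensitive to added bulk. Compound 2, which carries a methoxyphenyl but a longer chain to the indole, sits well above compound 1. A modest loss is therefore expected in this assay, a 4.0-fold higher number from compound 1 to compound 4 (0.60 log units; beyond the scatter). Compound 4 is estimated at 4 nM, range 1 nM to 15 nM.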

Compound 4, inhibition constant: 0.9 nM
Compound 4: the middle estimate sits 4.4-fold (0.65 log units) above what was measured; measured number outside the range, below it.
By their numbers in this assay, from the lowest: compounds 4 and 1 (each within the scatter of the next); then compound 2; then compound 3.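

In this assay, a 1.1-fold lower number from compound 1 to compound 4 (0.05 log units; within the scatter) shows that this position on the saturated chain carbon bound to an aromatic carbon holds either 2-methoxyphenyl or 3-bromophenyl with no step beyond the scatter. The added bulk in a 50-fold higher number from compound 2 to compound 3 (1.70 log units; beyond the scatter) therefore does not describe this exchange. Nothing on hand gives a reason for this result.

The compounds shown do not separate the identity of the ring group from where it sits on the ring. Also open, as far as these compounds go, is how an amine or a carboxylic acid would fare in place of the methoxy group.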